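This account rests on a few compounds, and the source may have more. Where it says the series, first, only, none or still open, it means among the compounds named here.

In a functional assay on DU-145 cells (Homo sapiens) for inhibition, read by trypan blue exclusion, with a stated time of 96 h (on this read-out lower numbers stand for stronger inhibition of growth and higher numbers for weaker inhibition of growth), the compounds measured so far read as follows:

- compound 1 `Cc1ccc(CS/C(=C/c2ccc(F)c(C)c2)C(=O)c2ccc(Cl)cc2)cc1` gives 25000 nM
- compound 2 `O=C(/C(=C\c1ccccc1OCc1ccccc1)SCc1ccc(F)cc1)c1ccc(Cl)cc1` gives 1000 nM
- compound 3 `Cc1ccc(S(=O)(=O)/C(=C/c2ccc(C)s2)C(=O)c2ccc(Cl)cc2)cc1` gives 50000 nM

Compound 1 at 25000 nM lies within the scatter of compound 3 at 50000 nM and so belongs with it at the upper end of this small set. Compound 2 at 1000 nM stands clearly lower than both, beyond the scatter.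

The next compound to be read is compound 4 `Cc1ccc(CS/C(=C/c2ccccc2F)C(=O)c2ccc(Cl)cc2)cc1`. It keeps the rest of compound 1, but 2-fluorophenyl comes in place of 4-fluoro-3-methylphenyl on a double-bonded chain carbon bound to a double-bonded chain carbon (2-fluorophenyl in place of 4-fluoro-3-methylphenyl on a double-bonded chain carbon bound to a double-bonded chain carbon).

Among the compounds with values here, no two measured compounds differ in one place only, so the data give no direct measure of such a change. Compound 2 differs from compound 1 in more than one place, which makes its low number weak support at best. A modest step in this assay is therefore expected, leaning towards stronger inhibition of growth and perhaps not far beyond the scatter. The expected move is a 2.1-fold lower number from compound 1 to compound 4 (0.32 log units; beyond the scatter) and it remains an estimate. For compound 4 the estimated value is 12000 nM with an expected range from 3000 nM to 40000 nM in this read-out.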

Compound 4, concentration for 50% growth inhibition: 10000 nM
For compound 4 the middle estimate is 1.2-fold (0.08 log units) above the measured one, and the stated range covers the measured number.
By their numbers in this assay, from the lowest: compound 2; then compound 4; then compounds 1 and 3 (each within the scatter of the next).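

Within the data shown here, compound 1 and compound 4 give the first direct reading of this place in this assay, where earlier comparisons could not isolate a single change. With 2-fluorophenyl in place of 4-fluoro-3-methylphenyl on a double-bonded chain carbon bound to a double-bonded chain carbon, the result is a 2.5-fold lower number from compound 1 to compound 4 (0.40 log units; beyond the scatter), so this swap gives a modest step that lies beyond the scatter, even though both groups have one six-membered aromatic ring of carbon only, no hydrogen-bond donors or acceptors and no net charge. Nothing in the data given accounts for the size or the direction of this step.

The pair changes the fluorine and the methyl group together, so it leaves open how much of the step belongs to each of them, and whether an amine or a carboxylic acid on the phenyl ring at this place, or a longer chain in its stead, would move the number further. Among these compounds, compound 2 and compound 3 each differ from compound 4 in more than one place, so no step to either of them can be read.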